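From 4-fluoro-3-methylphenyl to 4-methylphenyl: notes on the series

The compounds below may be only part of what the source reports. "The series", "measured", "known", "first", "only" and "open" are said of these compounds alone.

In a functional assay on SK-OV-3 cells (Homo sapiens) for cytotoxicity (a higher number here means a weaker inhibitor of growth, a lower number a stronger inhibitor of growth), compound 2 `COc1ccc(C2=C(c3ccc(SC)cc3)CC3CCCN3C2=O)cc1OC(=O)CNC(=O)OC(C)(C)C` gives 20000 nM. Compound 3 `CSc1ccc(C2=C(c3ccc(F)c(C)c3)C(=O)N3CCCC3C2)cc1` gives 300 nM, the lower of the two actual numbers, and the gap to compound 2 lies beyond the scatter. Compound 1 `COc1ccc(C2=C(c3cc(OC)c(OC)c(OC)c3)CC3CCCN3C2=O)cc1O` reads > 100000 nM, which is a limit of the assay and not a number.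

Compound 4 `CSc1ccc(C2=C(c3ccc(C)cc3)C(=O)N3CCCC3C2)cc1` is the next compound to be read. It carries 4-methylphenyl in place of 4-fluoro-3-methylphenyl on a double-bonded ring carbon. The 4-(methylsulfanyl)phenyl group stays in place on the neighbouring ring atom.

For the measured compounds named here, no measured pair isolates this change, so the expectation starts from compound 3 at 300 nM. A small move toward a higher number in this assay is expected, probably not beyond the scatter. The expected size is a 1.7-fold higher number from compound 3 to compound 4 (0.22 log units; within the scatter). For compound 4 the estimated value is 500 nM, with an expected range of 120 nM to 2500 nM.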

Compound 4, concentration for 50% growth inhibition: 9000 nM
Compound 4: the middle estimate sits 18-fold (1.26 log units) below what was measured; measured number outside the range, above it.
By their numbers in this assay, from the lowest: compound 3; then compound 4; then compound 2. At a limit, above all of these: compound 1.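

At the double-bonded ring carbon, the shared core tolerates no free exchange of aryl groups in this assay: 4-methylphenyl in place of 4-fluoro-3-methylphenyl gives a 30-fold higher number from compound 3 to compound 4 (1.48 log units; beyond the scatter), a large step. The position is therefore sensitive to the substitution pattern of this aromatic ring, even though both groups are six-membered aromatic rings of carbon only, with no hydrogen-bond donors or acceptors and no net charge. Nothing measured here accounts for the size of this step.

As far as these compounds go, it remains open which part of 4-fluoro-3-methylphenyl carries the step, a question that 4-fluorophenyl or 3-methylphenyl at this position would address. Also open, from the compounds shown here alone, is whether the step holds when 4-methoxyphenyl stands in place of the 4-(methylsulfanyl)phenyl group.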